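The source may report more compounds than this note shows. Statements on the series, on what has been measured and on what is new or still open speak of the compounds shown alone.

Compound 1 `CC1(C)[C@H]2CC[C@]1(C)N(Cc1cn(-c3ccc(Cl)cc3)nn1)C(=O)C2`: 160 nM
Compound 2 `CC1(C)[C@H]2CC[C@]1(C)N(Cc1cn(-c3ccccc3O)nn1)C(=O)C2`: 90 nM
Compound 3 `CC1(C)[C@H]2CC[C@]1(C)N(Cc1cn(-c3ccc(F)cc3)nn1)C(=O)C2`: 200 nM

In a functional assay on OVCAR-3 cells (Homo sapiens) for inhibition, read by MTT assay, with a stated time of 24 h (a lower number here means a stronger inhibitor, a higher number a weaker inhibitor), compound 3 gives 200 nM, the top of the three numbers; the gap to compound 1 is small, a 1.3-fold higher number from compound 1 to compound 3 (0.10 log units; within the scatter), while the gap to compound 2 is larger, a 2.2-fold higher number from compound 2 to compound 3 (0.35 log units; beyond the scatter). Compound 4 `CC1(C)[C@H]2CC[C@]1(C)N(Cc1cn(-c3cccc(Br)c3)nn1)C(=O)C2` carries 3-bromophenyl in place of 4-fluorophenyl on an aromatic nitrogen. For the measured compounds named here, the only measured step that bears on a halogen swap is a 1.3-fold higher number from compound 1 to compound 3 (0.10 log units; within the scatter), which stayed within the scatter; no measured pair tells how moving from a 4-substituted to a 3-substituted phenyl acts. Compound 4 is therefore expected to sit close to compound 3, with an estimated step of a 1.1-fold lower number from compound 3 to compound 4 (0.05 log units; within the scatter), not beyond the scatter. For compound 4 the estimate is 180 nM, in the range 80 nM to 400 nM.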

Compound 4, half-maximal inhibitory concentration: 30 nM
Beside the measured number, compound 4's estimate is 6.0-fold (0.78 log units) above it, and the stated range ends above it.
By their numbers in this assay, from the lowest: compound 4; then compounds 2, 1 and 3 (each within the scatter of the next, the first and the last beyond it).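

In this assay 3-bromophenyl on the aromatic nitrogen moves the number past the scatter, with a 6.7-fold lower number from compound 3 to compound 4 (0.82 log units; beyond the scatter) and a 5.3-fold lower number from compound 1 to compound 4 (0.73 log units; beyond the scatter) and also a 3.0-fold lower number from compound 2 to compound 4 (0.48 log units; beyond the scatter) as the steps. Compound 4 is the strongest of the four, and this position proves far more responsive than the halogen swap between compound 1 and compound 3 indicated.

From the compounds shown here alone, the step changes both the halogen and its place on the phenyl ring, so their shares stay open, as does the outcome with an amine or carboxylic acid on that ring. No available data explain the drop.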